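Methyl on the Amine: From Compound 1 to Compound 4

The source may hold more compounds than are shown below. What is called first, only, known or untested is meant among the compounds shown, and "the series" means these compounds.

Compound 1 `COc1c(N2CC[C@@H](N)C2)c(F)cc2c(=O)c(C(=O)O)cn(Cc3ccc(-c4ccccc4)cc3)c12` — 92200 nM
Compound 2 `COC(=O)c1cn(Cc2ccc(-c3ccccc3)cc2)c2c(OC)c(N3CC[C@@H](CN)C3)c(F)cc2c1=O` — 71400 nM
Compound 3 `CNCCNc1cc2c(cc1F)c(=O)c(C(=O)O)cn2Cc1ccc(-c2ccccc2)cc1` — a limit only, > 200000 nM

All three were tested in an assay on isolated protein for inhibition of DNA topoisomerase 1 (Homo sapiens), with a stated time of 15 min; a lower number here means a stronger inhibitor, a higher number a weaker inhibitor. Compound 1 carries the higher of the two numbers reported, but its gap to compound 2 lies within the usual scatter, so the two read as alike. Compound 3 sits at the limit of > 200000 nM in this assay, at which 1 of the 3 values shown sits, which is a limit and not a number. Compound 4 `CN[C@@H]1CCN(c2c(F)cc3c(=O)c(C(=O)O)cn(Cc4ccc(-c5ccccc5)cc4)c3c2OC)C1` is not yet measured; it differs from compound 1 by methyl in place of hydrogen on an amine nitrogen. Among the compounds with values here, no measured pair shows what such a change is worth here, so the step is expected to be small, in neither direction beyond the scatter: a 1.0-fold lower number from compound 1 to compound 4 (0.01 log units; within the scatter). Compound 4 is therefore estimated at 90000 nM, with a likely range from 40000 nM to 200000 nM.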

Compound 4, half-maximal inhibitory concentration: 57700 nM
Compound 4: middle estimate off by 1.6-fold (0.19 log units), on the high side; the range from low to high includes it.
By their numbers in this assay, from the lowest: compounds 4, 2 and 1 (each within the scatter of the next). At a limit, above all of these: compound 3.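

Methyl in place of hydrogen on an amine nitrogen gives a 1.6-fold lower number from compound 1 to compound 4 (0.20 log units; within the scatter), the first measured reading of this change among these compounds. Going from 3-aminopyrrolidin-1-yl to 3-(methylamino)pyrrolidin-1-yl, this nitrogen takes one added carbon without a shift beyond the usual scatter. Nothing in the data shown bears on why this step is so small.

As far as these compounds go, whether a larger group on this nitrogen, such as ethyl or benzyl, would move the number beyond the scatter remains open. So does the outcome for a tertiary dimethylamine at the same place.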